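From 3-methylphenyl to 2-bromophenyl on a sulfonamide nitrogen

The source may hold more compounds than are shown below. What is called first, only, known or untested is meant among the compounds shown, and "the series" means these compounds.

In a functional assay on MCF7 cells (Homo sapiens) for antiproliferative activity, read by MTT assay, with a stated time of 72 h (on this read-out lower numbers stand for stronger inhibition and higher numbers for weaker inhibition), compound 1 (`Cc1cccc(N(C)S(=O)(=O)C2CC3OC2C(c2ccc(NC(=O)CCCCCCC(=O)O)cc2)=C3c2ccc(O)cc2)c1`) gives 30200 nM and compound 2 (`CCN(c1cccc(C)c1)S(=O)(=O)C1CC2OC1C(c1ccc(NC(=O)CCCCCCC(=O)O)cc1)=C2c1ccc(O)cc1`) gives 31800 nM. Within the data shown here, these are the only two numbers available, and they lie within the scatter of each other, so compound 2 cannot be ranked against compound 1.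

Compound 3 (`CCN(c1ccccc1Br)S(=O)(=O)C1CC2OC1C(c1ccc(NC(=O)CCCCCCC(=O)O)cc1)=C2c1ccc(O)cc1`) has 2-bromophenyl in place of 3-methylphenyl on a sulfonamide nitrogen.

Among the measured compounds shown here, one measured step bears on this region, a 1.1-fold higher number from compound 1 to compound 2 (0.02 log units; within the scatter). It turns the methyl on the sulfonamide nitrogen into an ethyl, and it stays within the scatter. The aromatic group is the same in both compounds, so no measurement tests the present exchange directly, and the expectation is correspondingly loose. With no evidence for a direction, the value of compound 2 at 31800 nM serves as the anchor, and no change beyond the scatter is expected. The estimate amounts to a 1.1-fold lower number from compound 2 to compound 3 (0.06 log units; within the scatter), an expected step within the scatter. For compound 3 the estimated value is 28000 nM, with an expected range from 11000 nM to 70000 nM.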

Compound 3, half-maximal inhibitory concentration: > 100000 nM
Compound 3 ended at the assay's limit; the forecaster's own chance of this, stated with the estimate: 15%; middle value at least 3.5-fold (0.55 log units) from the limit.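

The aromatic group on the sulfonamide nitrogen responds where the saturated chain carbon did not. In this assay, 2-bromophenyl in place of 3-methylphenyl gives an at least 3.1-fold higher number from compound 2 to compound 3 (0.49 log units; beyond the scatter), whereas methyl in place of hydrogen on the chain carbon gave a 1.1-fold higher number from compound 1 to compound 2 (0.02 log units; within the scatter), which stayed within the scatter. Read as a single exchange of the whole amino group on the sulfonyl sulfur, the change gives an at least 3.3-fold higher number from compound 1 to compound 3 (0.51 log units; beyond the scatter), a step of similar printed size. Compound 3 reaches a limit of the assay, not a number, so both steps give only a lower bound on the size of the change: the limit of > 100000 nM in this assay, at which 1 of the 3 values shown sits.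

On these data alone, how much weaker compound 3 really is remains open, and so does whether the step follows the bromine itself or where it sits on the ring. Compounds carrying 3-bromophenyl or 2-methylphenyl on the same nitrogen, with the ethyl group kept, would separate these two readings, and unsubstituted phenyl would show what either substituent adds.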